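This account rests on a few compounds, and the source may have more. Where it says the series, first, only, none or still open, it means among the compounds named here.

Values in a functional assay on A549 cells (Homo sapiens) for antiproliferative activity, read by MTT assay, with a stated time of 72 h (a higher number here means a weaker inhibitor, a lower number a stronger inhibitor), are as follows
- Compound 1 `NC1=NC2(CCSCC2)N(OCCCOc2ccc(Cl)c(Cl)c2)C(N)=N1` gives 1 nM
- Compound 2 `COc1ccc(OCCCON2C(N)=NC(N)=NC23CCOCC3)cc1` gives 660 nM
- Compound 3 `NC1=NC2(CCSCC2)N(OCCCOc2ccc(Br)cc2)C(N)=N1` gives 740 nM

The value of compound 2 lies within the scatter of compound 3 and far from the much lower value of compound 1. Compound 4 `NC1=NC2(CCOCC2)N(OCCCOc2ccc(F)cc2)C(N)=N1` keeps the core of compound 2 and has yet to be measured. The difference is fluoro in place of methoxy on an aromatic carbon and amounts to fluoro in place of methoxy on an aromatic carbon.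

Going by the values given here, no measured step makes this exact change. The closest is the large step of a 740-fold higher number from compound 1 to compound 3 (2.87 log units; beyond the scatter) on another core, but it starts from the 3,4-dichlorophenyl group, which neither compound 2 nor compound 4 carries. Compound 3, with its 4-bromophenyl group (740 nM), and compound 2, with its 4-methoxyphenyl group (660 nM), give values within the scatter of each other despite their different cores. No step beyond the scatter is therefore expected in this assay, and no direction can be favoured.

The estimated step is a 1.1-fold lower number from compound 2 to compound 4 (0.04 log units; within the scatter) and would stay within the scatter. For compound 4 the expected value is 600 nM within an estimated range of 150 nM to 2000 nM in this assay.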

Compound 4, half-maximal inhibitory concentration: 1060 nM
The estimate for compound 4 lay 1.8-fold (0.25 log units) below the measured number; the measured number falls inside the stated range.
By their numbers in this assay, from the lowest: compound 1; then compounds 2, 3 and 4 (each within the scatter of the next).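

In this assay, fluoro in place of methoxy on the aromatic carbon gives a 1.6-fold higher number from compound 2 to compound 4 (0.21 log units; within the scatter), which stays within the scatter. The earlier compounds shown here compared this position only across different cores, whereas this pair reads the change directly on a single core and shows that 4-methoxyphenyl and 4-fluorophenyl cannot be told apart in this assay. Nothing at hand offers an explanation for this result.

The compounds shown leave open whether 3,4-dichlorophenyl, which compound 1 carries with 1 nM, would hold such a value on the core of compound 2. They also leave open how an amine or a carboxylic acid would read at this same position on the aromatic ring.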